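Dichloroacetamides in A549 Cells: From Methyl to Trifluoromethyl

The compounds below may be only part of what the source reports. "The series", "measured", "known", "first", "only" and "open" are said of these compounds alone.

Measured in a functional assay on A549 cells (Homo sapiens) for cytotoxicity, read by MTT assay, with a stated time of 68 h; on this read-out higher numbers stand for weaker inhibition and lower numbers for stronger inhibition:
- Compound 1 `COc1ccc(-c2cc(NC(=O)C(Cl)Cl)cc(-c3ccc(OC)cc3)c2)cc1`: 20800 nM
- Compound 2 `O=C(Nc1cccc(-c2ccc(-c3ccccc3)cc2)c1)C(Cl)Cl`: > 50000 nM (a limit of the assay)
- Compound 3 `Cc1ccc(-c2cccc(NC(=O)C(Cl)Cl)c2)cc1`: 8300 nM

Compound 3 has the lower of the two actual numbers at 8300 nM, while compound 1 stands higher at 20800 nM. Compound 2 gives only a limit, > 50000 nM. Compound 4 `O=C(Nc1cccc(-c2ccc(C(F)(F)F)cc2)c1)C(Cl)Cl` differs from compound 3 by one change: trifluoromethyl in place of methyl on an aromatic carbon. Going by the values given here, one measured step bears on this swap: an at least 6.0-fold lower number from compound 2 to compound 3 (0.77 log units; beyond the scatter), where methyl replaced phenyl. Given that step, a modest move back towards compound 2 is expected in this assay, meaning a somewhat higher number. The expected size is a 1.4-fold higher number from compound 3 to compound 4 (0.16 log units; within the scatter). For compound 4 the estimate is 12000 nM, with an expected range of 5000 nM to 30000 nM.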

Compound 4, half-maximal inhibitory concentration: 23500 nM
The estimate for compound 4 lay 2.0-fold (0.29 log units) below the measured number, and the stated range covers the measured number.
By their numbers in this assay, from the lowest: compound 3; then compounds 1 and 4 (each within the scatter of the next). At a limit, above all of these: compound 2.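

In this assay, the aromatic carbon para to a large group responds even to a swap that adds no ring: a 2.8-fold higher number from compound 3 to compound 4 (0.45 log units; beyond the scatter). Trifluoromethyl still gives a lower number than phenyl on that carbon, with an at least 2.1-fold lower number from compound 2 to compound 4 (0.32 log units; beyond the scatter), so the three groups run methyl, trifluoromethyl, phenyl, from lowest to highest. Compound 2 has only a limit, not a true number: the limit of > 50000 nM in this assay, at which 1 of the 4 values shown sits.

From the compounds shown here alone, how an amine or a carboxylic acid on this carbon would read remains open. These numbers also do not explain why trifluoromethyl and methyl differ.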